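The source may report more compounds than this note shows. Statements on the series, on what has been measured and on what is new or still open speak of the compounds shown alone.

Compound 1 `COc1cc(OC)c2c(=O)cc(-c3ccc(OCCBr)cc3)oc2c1`: "not active" (no number reported)
Compound 2 `COc1cc(OC)c2c(=O)cc(-c3ccc(OCCF)cc3)oc2c1`: "not active" (no number reported)
Compound 3 `COc1cc(OC)c2c(=O)cc(-c3ccc(OC4CCN(C)CC4)cc3)oc2c1`: 28%

In a functional assay (Homo sapiens) for antiproliferative activity, read by resazurin assay, with a stated time of 48 h, tested at 5 uM (on this read-out higher numbers stand for a stronger effect at the one concentration tested and lower numbers for a weaker effect), compound 1 is reported as "not active" (no number reported) and compound 2 as "not active" (no number reported), neither with a number. Compound 3 is the only one of the three with a figure: in this assay compound 3 gives 28%, which leaves it without a measured neighbour to compare against. Compound 4 `COc1cc(OC)c2c(=O)cc(-c3ccc(OCCCN(C)C)cc3)oc2c1` has not yet been tested. It differs from compound 3 in one place: 3-(dimethylamino)propyl in place of 1-methylpiperidin-4-yl on an oxygen on an aromatic ring. For the measured compounds named here, no step between measured compounds of this set is known, so the size of this change can only be guessed. Compound 4 is expected to land close to compound 3, with a step of a number 3 percentage points lower from compound 3 to compound 4 (within the scatter) in this assay, which is not expected to go beyond the usual scatter. Compound 4 is therefore estimated at 25%, within the range 5% to 50%.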

Compound 4, a percentage reported as inhibition, at one concentration (the size of the read-out at that concentration, not a potency): 36%
Compound 4: the middle estimate sits 11 percentage points below what was measured, within the range that was stated.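

In this assay, for the compounds shown here, the exchange of 1-methylpiperidin-4-yl for 3-(dimethylamino)propyl on the oxygen gives a number 8 percentage points higher from compound 3 to compound 4 (within the scatter) and is the first step that can be read at this position. It shows that the six-membered ring can give way to an open chain carrying its nitrogen without a difference beyond the scatter. Nothing measured here explains this result. Still open, as far as these compounds go, is how a 2-(dimethylamino)ethyl chain, or a morpholine or a primary amine at the end of the propyl chain, would read.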